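One chloro exchanged for fluoro on the benzyl group

The compounds below may be only part of what the source reports. "The series", "measured", "known", "first", "only" and "open" are said of these compounds alone.

Values so far in a functional assay on K562 cells (Homo sapiens) for antiproliferative activity, with a stated time of 72 h (on this read-out higher numbers stand for weaker inhibition and lower numbers for stronger inhibition), are these:
Compound 1 `OC[C@H]1O[C@@H](n2cnc3c(NCc4ccccc4Br)ncnc32)[C@H](O)[C@@H]1O` gives 10000 nM as a number
Compound 2 `COc1cccc(CNc2ncnc3c2ncn3[C@@H]2O[C@H](CO)[C@@H](O)[C@H]2O)c1` gives > 166000 nM as a limit
Compound 3 `OC[C@H]1O[C@@H](n2cnc3c(NCc4ccc(Cl)cc4Cl)ncnc32)[C@H](O)[C@@H]1O` gives 106000 nM as a number

Compound 3 holds the higher of the two true numbers, and compound 1 is its nearest neighbour, with an 11-fold higher number from compound 1 to compound 3 (1.03 log units; beyond the scatter) separating them. Compound 2 is known only as a limit. That leaves an at least 1.5-fold lower number from compound 2 to compound 3 (0.19 log units; that floor lies within the scatter) as all that can be said of that pair.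

Compound 4 `OC[C@H]1O[C@@H](n2cnc3c(NCc4ccc(F)cc4Cl)ncnc32)[C@H](O)[C@@H]1O` differs from compound 3 by a single exchange, fluoro in place of chloro on an aromatic carbon in all. It is fluoro in place of chloro on an aromatic carbon, para to a large group and meta to a chloro group, so 2,4-dichlorobenzyl becomes 2-chloro-4-fluorobenzyl.

Going by the values given here, no measured step makes this exact exchange. The closest evidence is an at least 16-fold higher number from compound 1 to compound 2 (1.22 log units; beyond the scatter) and an 11-fold higher number from compound 1 to compound 3 (1.03 log units; beyond the scatter) as well, both large, and each replaces the whole substituted phenyl group of compound 1. Those changes are broader than one halogen exchange, so a much smaller move is expected here, though these steps warn that this group can matter. The step expected in this assay is a 1.3-fold lower number from compound 3 to compound 4 (0.12 log units; within the scatter) and would probably stay within the scatter. For compound 4 the estimated value is 80000 nM with 25000 nM to 200000 nM as its expected range.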

Compound 4, half-maximal inhibitory concentration: 15600 nM
The estimate for compound 4 lay 5.1-fold (0.71 log units) above the measured number, outside the stated range (below it).
By their numbers in this assay, from the lowest: compounds 1 and 4 (each within the scatter of the next); then compound 3. At a limit, above all of these: compound 2.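

In this assay, going by these compounds alone, the single exchange of chloro for fluoro, para to a large group and meta to a chloro group, gives a 6.8-fold lower number from compound 3 to compound 4 (0.83 log units; beyond the scatter), so this one position alone can move the result modestly but beyond the scatter, which the earlier replacements of the whole substituted phenyl group could not isolate. The 2-chloro-4-fluorophenyl group in place of 2-bromophenyl gives a 1.6-fold higher number from compound 1 to compound 4 (0.19 log units; within the scatter), so these two groups cannot be put in any order on this read-out, although 2,4-dichlorophenyl stood apart from 2-bromophenyl beyond the scatter. Set against 3-methoxyphenyl, the new group gives an at least 10-fold lower number from compound 2 to compound 4 (1.02 log units; beyond the scatter), which is only a floor, the first of the two values being a limit of the assay: the limit of > 166000 nM in this assay, at which 1 of the 4 values shown sits.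

The compounds shown carry only halogens and a methoxy group on the benzyl group, so it remains open how a methyl, a trifluoromethyl or an amine at this same position would compare in this assay. As far as these compounds go, it also remains open whether fluoro in place of the remaining chloro group would move the result at all, or whether the step from chloro to fluoro would hold on a different core.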